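A Methyl Added to the Phenylsulfonyl of Compound 1

The compounds below may be only part of what the source reports. "The series", "measured", "known", "first", "only" and "open" are said of these compounds alone.

Compound 1 `COc1cc(Nc2nc3ccccc3nc2S(=O)(=O)c2ccccc2)cc(OC)c1` is the most potent of the three compounds measured in a functional assay on HL-60 cells (Homo sapiens) for cytotoxicity, read by MTT assay, with a stated time of 72 h (a lower number here means a stronger inhibitor, a higher number a weaker inhibitor), where compound 1 gives 50 nM. Compound 2 `O=S(=O)(c1ccccc1)c1nc2ccccc2nc1Nc1ccc(F)cc1` gives 1010 nM, and compound 3 `O=S(=O)(c1ccccc1)c1nc2ccccc2nc1Nc1ccc(C(F)(F)F)cc1` gives 300 nM. Both steps away from compound 1 lie beyond the scatter: a 20-fold higher number from compound 1 to compound 2 (1.31 log units; beyond the scatter) and a 6.0-fold higher number from compound 1 to compound 3 (0.78 log units; beyond the scatter), while a 3.4-fold lower number from compound 2 to compound 3 (0.53 log units; beyond the scatter). All three of these steps alter only the group on the nitrogen on the aromatic ring of the shared core. Compound 4 `COc1cc(Nc2nc3ccccc3nc2S(=O)(=O)c2ccc(C)cc2)cc(OC)c1` differs from compound 1 at a different place: methyl in place of hydrogen on an aromatic carbon, so that the phenylsulfonyl becomes a (4-methylphenyl)sulfonyl. For the measured compounds named here, no measured step touches this part of the molecule, and the numbers in hand give no indication of whether the methyl helps or harms. The step from compound 1 to compound 4 in this assay is therefore expected to be a 1.2-fold higher number from compound 1 to compound 4 (0.08 log units; within the scatter), that is, none beyond the scatter. Compound 4 is expected to give 60 nM, with a range from 20 nM to 200 nM.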

Compound 4, half-maximal inhibitory concentration: 20 nM
The estimate for compound 4 lay 3.0-fold (0.48 log units) above the measured number; the measured number falls inside the stated range.
By their numbers in this assay, from the lowest: compound 4; then compound 1; then compound 3; then compound 2.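

For the compounds shown here, the phenylsulfonyl, which no earlier step had touched, turns out to matter in this assay: methyl in place of hydrogen on an aromatic carbon, para to a large group, gives a 2.5-fold lower number from compound 1 to compound 4 (0.40 log units; beyond the scatter). Going by these compounds alone, the earlier steps changed only the group on the nitrogen, so this is the first sign that a second part of the molecule also moves the number, and here a small group added to compound 1 improves on it rather than harming it. Nothing shown gives a reason for this shift.

The compounds shown leave open whether the shift belongs to methyl itself or would also appear with an ethyl, a methoxy, an amine or a carboxylic acid at this place. They also leave open whether the same methyl would lower the numbers of compound 2 and compound 3, which carry other groups on the nitrogen.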